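Swapping the amino group of compound 2

The source may hold more compounds than are shown below. What is called first, only, known or untested is meant among the compounds shown, and "the series" means these compounds.

In an in vitro ADME assay on the whole organism (small intestine) for pharmacokinetics, with Rattus norvegicus as the target (on this read-out lower numbers stand for a shorter-lived compound and higher numbers for a longer-lived compound), compound 1 (`C/C(=C\c1ccc(C(=O)Oc2ccc(C(=N)N)cc2)cc1)C(=O)N(CC(=O)O)C1CCCC1`) gives 0.7 h as its half-life. Compound 2 (`CCN(CC(=O)O)C(=O)/C(C)=C/c1ccc(C(=O)Oc2ccc(C(=N)N)cc2)cc1`) gives > 1 h as a limit of the assay and not a number. Compound 3 (`C=CCN(CCC(=O)O)C(=O)/C(C)=C/c1ccc(C(=O)Oc2ccc(C(=N)N)cc2)cc1`) carries allyl(2-carboxyethyl)amino in place of (carboxymethyl)(ethyl)amino on a carbonyl carbon. Among the compounds with values here, the one measured step bearing on this change is an at least 1.4-fold higher number from compound 1 to compound 2 (0.15 log units; that floor lies within the scatter) and its floor lies within the scatter. No step beyond the scatter is therefore expected in this assay for this change. The expected step is a step that the limit leaves unreadable from compound 2 to compound 3 on this reading. Compound 3 is estimated at 1.2 h with an expected range from 0.6 h to 3 h when measured.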

Compound 3, half-life: > 1 h
Compound 3: only a limit was reported (the forecaster's own chance of this, stated with the estimate: 45%); the middle value does not contradict the limit.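

In this assay compound 3 gives > 1 h, which is a limit of the assay and not a number. Allyl(2-carboxyethyl)amino on the carbonyl carbon, with its longer acid chain and extra double bond, gives an at least 1.4-fold higher number from compound 1 to compound 3 (0.15 log units; that floor lies within the scatter). The steps between compound 2 and compound 3 cannot be read, because the read-out stops at the same limit: the limit of > 1 h in this assay, at which 2 of the 3 values shown sit.

Going by these compounds, the true half-lives of compound 2 and compound 3 remain open, so no order between them can be given. Also open, on these data alone, is how a tetrazole in place of the carboxylic acid would read here.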